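Alpha-carbon swap: cyclopentyl to 4-fluorophenyl

A few compounds are considered here, and "the series" means these few. Any claim that something is new, unique, unknown or untested is made for them only; others in the source may bear on it.

Measured so far:
compound 1 `CC1CCN(c2nc(C(F)(F)F)ccc2CNC(=O)C(c2ccc(NS(C)(=O)=O)c(F)c2)C2CCCC2)CC1`, in an assay on CHO cells for antagonist activity at transient receptor potential cation channel subfamily V member 1 (Homo sapiens), read by FLIPR (on this read-out higher numbers stand for weaker inhibition and lower numbers for stronger inhibition), compound 1 gives 88.7 nM
compound 2 `CS(=O)(=O)Nc1ccc(C(C(=O)NCc2ccc(C(F)(F)F)nc2SC2CCCCC2)C2CCCC2)cc1F`, compound 2 gives 103 nM

Compound 1 holds the lower of the two numbers, but the step of a 1.2-fold higher number from compound 1 to compound 2 (0.06 log units; within the scatter), a change at the aromatic carbon, separates them by nothing beyond the scatter. Compound 3 `CC1CCN(c2nc(C(F)(F)F)ccc2CNC(=O)C(c2ccc(F)cc2)c2ccc(NS(C)(=O)=O)c(F)c2)CC1` differs from compound 1 by 4-fluorophenyl in place of cyclopentyl on a saturated chain carbon bound to an aromatic carbon and a carbonyl carbon. Going by the values given here, no measured step touches this position, so the data give no guide to its direction or size. Compound 3 is therefore expected near compound 1, estimated at 120 nM with a wide range from 35 nM to 450 nM. This estimate means a step of a 1.4-fold higher number from compound 1 to compound 3 (0.13 log units; within the scatter) for compound 3, expected to stay within the scatter.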

Compound 3, inhibition constant: 3.4 nM
Compound 3: the middle estimate sits 35-fold (1.55 log units) above what was measured, outside the stated range (below it).
By their numbers in this assay, from the lowest: compound 3; then compounds 1 and 2 (each within the scatter of the next).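

In this assay, going by these compounds alone, the saturated chain carbon bound to an aromatic carbon and a carbonyl carbon proves a strong lever: 4-fluorophenyl in place of cyclopentyl gives a 26-fold lower number from compound 1 to compound 3 (1.42 log units; beyond the scatter), whereas the one earlier step, at another position, stayed within the scatter. No measurement bears on the reason for this step. Open, as far as these compounds go, is whether the gain needs the fluorine or the aromatic ring, which a plain phenyl or a cyclohexyl at this carbon would separate. Also open, from the compounds shown here alone, is whether 4-fluorophenyl here gives a similar step with the cyclohexylsulfanyl of compound 2.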